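The source may hold more compounds than are shown below. What is called first, only, known or untested is meant among the compounds shown, and "the series" means these compounds.

Measured so far in an ADME assay on MOLT-3 cells (Homo sapiens) for cytotoxicity, with a stated time of 7 days; a lower number here means that less compound is tolerated, a higher number that more compound is tolerated:
- compound 1 `C=CCOc1nc(N)nc2c1ncn2/C=C1/CC1(CO)CO` gives > 20000 nM as a limit
- compound 2 `CCCCCOc1nc(N)nc2c1ncn2/C=C1/CC1(CO)CO` gives > 20000 nM as a limit

Compound 2 stands at > 20000 nM in this assay, which is a limit of the assay and not a number. Within the data shown here, the series so far reads as the limit of > 20000 nM in this assay, at which 2 of the 2 values shown sit, and offers no numerical value.

Compound 3 `CCCCOc1nc(N)nc2c1ncn2/C=C1/CC1(CO)CO` is still to be measured. It differs from compound 2 by hydrogen in place of methyl on a saturated chain carbon, four bonds along the chain from an oxygen on an aromatic ring. Among the measured compounds shown here, the one measured step that bears on this change is a step that the two limits leave unreadable from compound 1 to compound 2, also a change in the chain on that oxygen. Its size cannot be read, so it only weakly guides the new step.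

No step beyond the scatter is expected in this assay, in either direction. The expected change is a step that the limit leaves unreadable from compound 2 to compound 3 and it has no favoured direction. For compound 3 the estimated value is 25000 nM, with an expected range from 12000 nM to 50000 nM and a good chance that only a limit is reported.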

Compound 3, half-maximal cytotoxic concentration: > 20000 nM
Compound 3: no number, only a limit; the forecaster's own chance of this, stated with the estimate: 85%; the middle value is on the limit's open side.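

In this assay compound 3 gives > 20000 nM as a limit and not a number. Among these compounds, no step among compound 1, compound 2 and compound 3 can be read, as all three share one reading: the limit of > 20000 nM in this assay, at which 3 of the 3 values shown sit.

The compounds shown leave open how much compound is tolerated in each case and whether the chain on that oxygen changes it.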